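The source may report more compounds than this note shows. Statements on the series, on what has been measured and on what is new or still open speak of the compounds shown alone.

Measured so far in an ADME assay on NIH3T3 cells (Mus musculus) for cytotoxicity, read by XTT assay, with a stated time of 24 h; a lower number here means a stronger inhibitor, a higher number a weaker inhibitor:
- compound 1, `Cc1ccc(-c2csc(N3N=C(c4ccc(C)s4)CC3c3ccc(F)cc3)n2)cc1`
- compound 2, `Cc1ccc(C2=NN(c3nc(-c4ccc(F)cc4)cs3)C(c3ccc(F)cc3)C2)s1`
- compound 3, `COc1ccc(-c2csc(N3N=C(c4ccc(C)s4)CC3c3ccc(F)cc3)n2)cc1`

In this assay compound 1 gives only a limit, > 500 ug/mL. Compound 2 likewise gives only a limit, > 500 ug/mL. Compound 3 gives 147 ug/mL. Compound 2 thus sits at the limit noted in the limit of > 500 ug/mL in this assay, at which 2 of the 3 values shown sit, together with compound 1, and only compound 3 has a number.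

Compound 4, `Fc1ccc(-c2csc(N3N=C(c4ccc(Cl)s4)CC3c3ccc(F)cc3)n2)cc1`, differs from compound 2 by chloro in place of methyl on an aromatic carbon. Among the compounds with values here, no measured step touches this position on the thiophene; a step that the two limits leave unreadable from compound 1 to compound 2 is unreadable, while an at least 3.4-fold lower number from compound 1 to compound 3 (0.53 log units; beyond the scatter) and an at least 3.4-fold lower number from compound 2 to compound 3 (0.53 log units; beyond the scatter) concern the other aryl ring and show that a change there can pull the number down. For compound 4 the expectation is that this assay again reports a limit or a number near it, with a number no higher from compound 2 to compound 4 (the limit leaves the size open) expected. The estimate for compound 4 is 500 ug/mL, between 200 ug/mL and 1000 ug/mL.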

Compound 4, half-maximal inhibitory concentration: > 500 ug/mL
Compound 4 was reported as a limit; the forecaster's own chance of this, stated with the estimate: 65%; the middle value lies on the limit itself.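

Compound 2 and compound 4 both stay at a limit in this assay, so no step between them can be read: the limit of > 500 ug/mL in this assay, at which 3 of the 4 values shown sit.

Open, as far as these compounds go, is whether 5-chlorothiophen-2-yl in place of 5-methylthiophen-2-yl shifts the number at all in this assay.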